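Phenyl to neopentyl: notes on compound 3 and compound 4

A few compounds are considered here, and "the series" means these few. Any claim that something is new, unique, unknown or untested is made for them only; others in the source may bear on it.

Measured in a functional assay on a cell-free system (plasma, Homo sapiens), with a stated time of 3 min; a higher number here means a weaker inhibitor, a lower number a stronger inhibitor:
- compound 1 `O=C(NCc1cc(Cl)ccc1-n1cnnn1)[C@@H]1C[C@@H]2C[C@@H]2N1C(=O)[C@H](O)CC1CC1` gives 1700 nM
- compound 2 `O=C(NCc1cc(Cl)ccc1-n1cnnn1)[C@@H]1CC=NN1C(=O)[C@H](O)c1ccccc1F` gives 1100 nM
- compound 3 `O=C(NCc1cc(Cl)ccc1-n1cnnn1)[C@@H]1CC=NN1C(=O)[C@H](O)c1ccccc1` gives 840 nM

Compound 3 and compound 2 lie within the scatter of each other. Compound 1 has a higher number than compound 3, and that gap lies beyond the scatter.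

Compound 4 `CC(C)(C)C[C@@H](O)C(=O)N1N=CC[C@H]1C(=O)NCc1cc(Cl)ccc1-n1cnnn1` carries neopentyl in place of phenyl on a saturated chain carbon bound to a carbonyl carbon and an oxygen on a saturated carbon.

Among the compounds with values here, only one measured step touches this group: a 1.3-fold lower number from compound 2 to compound 3 (0.12 log units; within the scatter). It is hydrogen in place of fluoro on an aromatic carbon, and it stays within the scatter. It shows tolerance of a small change on the phenyl, but it says nothing about losing the phenyl altogether. Compound 1 has no phenyl either, but its core also differs, so its 1700 nM cannot be read as a clean step. The data therefore give no direction for this change. The expected result in this assay is no shift beyond the scatter, with the estimated step being a 1.2-fold higher number from compound 3 to compound 4 (0.08 log units; within the scatter). For compound 4 the estimated value is 1000 nM, with an expected range of 350 nM to 3000 nM.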

Compound 4, half-maximal inhibitory concentration: 590 nM
Beside the measured number, compound 4's estimate is 1.7-fold (0.23 log units) above it; measured number inside the range.
By their numbers in this assay, from the lowest: compounds 4, 3, 2 and 1 (each within the scatter of the next, the first and the last beyond it).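

In this assay, an aromatic ring is not needed on the saturated chain carbon bound to a carbonyl carbon and an oxygen on a saturated carbon: neopentyl in place of phenyl gives a 1.4-fold lower number from compound 3 to compound 4 (0.15 log units; within the scatter), and neopentyl in place of 2-fluorophenyl gives a 1.9-fold lower number from compound 2 to compound 4 (0.27 log units; within the scatter). The earlier step covered only a small change on the phenyl, whereas these two steps show that the whole six-membered aromatic ring of carbon only can give way to a group with no ring, and neither step lies beyond the scatter, so this position tolerates both kinds of group on the shared core without either being shown to be better. Nothing available gives a reason for this tolerance.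

The compounds shown carry only carbon groups at this position, with no hydrogen-bond donors or acceptors in the phenyl or the neopentyl, so it remains open whether an amine, a carboxylic acid or a longer chain would be tolerated as well. On these data alone, it also remains open whether neopentyl would give a similar number on the core of compound 1, which cannot be compared directly with compound 4 in its present form.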